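The compounds below may be only part of what the source reports. "The series", "measured", "known", "first", "only" and "open" are said of these compounds alone.

Measured compounds:
- compound 1, `CC#CCOC(=O)/C=C(C)/C=C/CC(C)CCCC(C)C`: 6.4
- compound 2, `CCC(C)OC(=O)/C=C(C)/C=C/CC(C)CCCC(C)(C)OC`: 6.49
- compound 3, `CC(/C=C/CC(C)CCCC(C)(C)C)=C\C(=O)OC(C)C`: 7.56

In a physicochemical assay for lipophilicity (a lower number here means a more polar compound, a higher number a more lipophilic compound), compound 1 gives the lowest of the three numbers. Compound 2 sits within the scatter of it, so no order between these two can be read; compound 3 lies well beyond the scatter, higher than compound 1. The step to the unmeasured compound 4, `CC(/C=C/CC(C)CCCC(C)C)=C\C(=O)N(C)C`, is this change: dimethylamino in place of (but-2-yn-1-yl)oxy on a carbonyl carbon. Going by the values given here, no measured pair shows this kind of change, so the expectation rests on compound 1 alone. The part that leaves is larger than the part that enters, and the ester becomes an amide; the number for compound 4 is expected to fall clearly beyond the scatter, downward. Starting from 6.4 for compound 1, compound 4 is estimated at 4.7, between 4 and 5.4, an expected step of a number 1.70 log units lower from compound 1 to compound 4 (beyond the scatter).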

Compound 4, partition coefficient: 4.94
Compound 4: middle estimate off by 0.24 log units, on the low side; low and high end bracket the measured number.
By their numbers in this assay, from the lowest: compound 4; then compounds 1 and 2 (each within the scatter of the next); then compound 3.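

Going by these compounds alone, putting dimethylamino in place of (but-2-yn-1-yl)oxy on a carbonyl carbon gives in this assay the first measured single-place step of the set: a number 1.46 log units lower from compound 1 to compound 4 (beyond the scatter). It shows that a change at this one position, with the rest of the molecule untouched, can move the number by a large amount. Nothing measured here explains the size of this step. Still open, as far as these compounds go, is whether the step follows from the amide nitrogen or from the shorter group, and a methoxy or a diethylamino group on the same carbonyl carbon would help separate the two.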